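Methyl to Hydrogen on an Aromatic Nitrogen: Two Cores Compared

The compounds below may be only part of what the source reports. "The series", "measured", "known", "first", "only" and "open" are said of these compounds alone.

Compound 1, `Nc1n[nH]c2cc(-c3ccccn3)[nH]c(=O)c12`: 41%
Compound 2, `Cn1nc(N)c2c(=O)[nH]c(-c3ccccn3)cc21`: 36%
Compound 3, `Cc1cc2c(cn1)c(N)nn2C`: -2%

All three compounds were tested in an assay on isolated protein for inhibition of MAP kinase-activated protein kinase 2 (Homo sapiens), read by mobility shift assay, tested at 30 uM; on this read-out lower numbers stand for less inhibition and higher numbers for more inhibition at the one concentration tested (going by the name of the read-out). Compound 1 and compound 2 share one core and differ only in hydrogen in place of methyl on an aromatic nitrogen. The step of a number 5 percentage points higher from compound 2 to compound 1 (within the scatter) is small, so these two compounds cannot be told apart on this read-out.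

Compound 3 rests on a different core, and the difference between the two cores is not broken down here. In this assay compound 3 gives the lowest of the three numbers, and its distance to compound 2 and to compound 1 is in each case beyond the scatter.

Compound 4, `Cc1cc2[nH]nc(N)c2cn1`, has not yet been measured. It differs from compound 3 in hydrogen in place of methyl on an aromatic nitrogen, and the description of the place is the same word for word as for the pair of compound 2 and compound 1, so this is the same change made on the other core. Among the measured compounds shown here, the only measured example of that change, from compound 2 to compound 1, moved the number by a number 5 percentage points higher from compound 2 to compound 1 (within the scatter), which is within the scatter. For the measured compounds named here, on that basis a step of similar size is expected from compound 3 to compound 4, namely a number 4 percentage points higher from compound 3 to compound 4 (within the scatter), because the one measured step of a number 5 percentage points higher from compound 2 to compound 1 (within the scatter) was small. Compound 4 is therefore estimated to give 2% in this assay, with a likely range from -10% to 15%. Whether the change behaves alike on the two cores is not settled by one example, and compound 4 itself will decide it.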

Compound 4, a percentage reported as inhibition, at one concentration (the size of the read-out at that concentration, not a potency): 7%
Estimate against measurement, compound 4: 5 percentage points below, and the stated range covers the measured number.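

Putting hydrogen in place of methyl on the aromatic nitrogen of the core of compound 3 gives, in this assay, a number 9 percentage points higher from compound 3 to compound 4 (within the scatter). Set beside the earlier step, the same change looks alike on the two cores: the same change on two cores in this assay, a number 5 percentage points higher (within the scatter) from compound 2 to compound 1 and a number 9 percentage points higher (within the scatter) from compound 3 to compound 4, 4 percentage points apart, within the scatter of two such steps

So in both pairs the swap of methyl for hydrogen produces no shift that can be told from ordinary scatter, and this holds on two cores that otherwise stand far apart in their numbers. That does not show that methyl and hydrogen are interchangeable at this place in general, since two pairs support no rule for other cores, and each number is a reading at one concentration, which says nothing about how potency would compare across a full dose range.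

The compounds shown leave open whether anything larger on this aromatic nitrogen, such as an ethyl group, a longer chain or a chain ending in an amine, would also leave the number in place. They also leave open what would happen if the amino group on the five-membered ring gave way to a different group, such as a carboxylic acid, on either core.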